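The source may report more compounds than this note shows. Statements on the series, on what has been measured and on what is new or still open speak of the compounds shown alone.

Within the data shown here, in a functional assay on the whole organism with Rattus norvegicus as the target (on this read-out higher numbers stand for an effect only at larger amounts of compound and lower numbers for an effect already at smaller amounts), two compounds sharing one core have numbers so far: compound 1 (`CCOC(=O)c1c(Cn2ccnc2)nc2cc(OC)c(OC)cc2c1-c1ccc(OC)c(OC)c1`) gives 7.7 mg/kg and compound 2 (`CCOC(=O)c1c(Cn2ccnc2CC)nc2cc(OC)c(OC)cc2c1-c1ccc(OC)c(OC)c1`) gives 9.1 mg/kg. Among the measured compounds shown here, compound 2 therefore stands level with compound 1, the only other measured compound. Compound 3 (`CCOC(=O)c1c(Cn2cncn2)nc2cc(OC)c(OC)cc2c1-c1ccc(OC)c(OC)c1`) has 1H-1,2,4-triazol-1-yl in place of 2-ethyl-1H-imidazol-1-yl on a saturated chain carbon bound to an aromatic carbon. For the measured compounds named here, the only measured step that bears on this is a 1.2-fold higher number from compound 1 to compound 2 (0.07 log units; within the scatter), where ethyl replaces hydrogen on an aromatic carbon. Going by the values given here, that step covers only the loss of the ethyl, and no measured compound carries the 1H-1,2,4-triazol-1-yl group. No shift beyond the scatter is therefore expected in this assay, though with wide uncertainty. The expected step is a 1.3-fold lower number from compound 2 to compound 3 (0.11 log units; within the scatter). For compound 3 the estimate is 7 mg/kg, with an expected range of 2 mg/kg to 20 mg/kg.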

Compound 3, dose for half-maximal effect: 2.6 mg/kg
Compound 3: middle estimate off by 2.7-fold (0.43 log units), on the high side, and the stated range covers the measured number.
By their numbers in this assay, from the lowest: compound 3; then compounds 1 and 2 (each within the scatter of the next).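

In this assay, the group on a saturated chain carbon bound to an aromatic carbon can shift the number beyond the scatter, which the ethyl step alone did not show: 1H-1,2,4-triazol-1-yl in place of 2-ethyl-1H-imidazol-1-yl gives a 3.5-fold lower number from compound 2 to compound 3 (0.54 log units; beyond the scatter). The comparison without the ethyl gives a 3.0-fold lower number from compound 1 to compound 3 (0.47 log units; beyond the scatter), so the shift also appears when 1H-imidazol-1-yl, with 2 hetero atoms in its ring, gives way to a ring with 3. Nothing available here explains this shift.

On these data alone, it remains open whether a 1H-tetrazol-1-yl or 1H-pyrazol-1-yl ring, or an open-chain amine such as dimethylamino, would behave like 1H-1,2,4-triazol-1-yl at this place. Also open, as far as these compounds go, is whether an ethyl group on the triazole ring would leave the number unchanged, as it did on the imidazole ring.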